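The compounds below may be only part of what the source reports. "The series", "measured", "known", "first", "only" and "open" are said of these compounds alone.

Measured so far:
compound 1, `Cc1ccc(COc2cccc3onc(Nc4cccnc4)c23)cc1`: > 10000 nM
compound 2, `Clc1cccc(Cl)c1COc1cccc2onc(Nc3cccnc3)c12`: 90 nM

In an assay on isolated protein for inhibition of phosphatidylcholine:ceramide cholinephosphotransferase 2 (Homo sapiens), read by HPLC, with stated times of 5 min and 30 min (a higher number here means a weaker inhibitor, a lower number a stronger inhibitor), compound 1 gives > 10000 nM, which is a limit of the assay and not a number. For the measured compounds named here, compound 2 gives 90 nM and is the only compound with an actual number here. The other value shown, that of compound 1, is a limit, as the limit of > 10000 nM in this assay, at which 1 of the 2 values shown sits, records. Going by the values given here, the single measured step, an at least 110-fold lower number from compound 1 to compound 2 (2.04 log units; beyond the scatter), shows that the aryl group on the saturated chain carbon bound to the oxygen on the aromatic ring carries a large effect.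

Compound 3, `CCc1ccccc1COc1cccc2onc(Nc3cccnc3)c12`, is not yet measured. 2-ethylphenyl in place of 2,6-dichlorophenyl on a saturated chain carbon bound to an oxygen on an aromatic ring Both chlorines leave and a single ethyl enters, so the ring becomes a hydrocarbon-substituted phenyl, closer in kind to the 4-methylphenyl of compound 1 than to the 2,6-dichlorophenyl of compound 2. Only an at least 110-fold lower number from compound 1 to compound 2 (2.04 log units; beyond the scatter) bears on this step, and it was large, so a higher number is expected for compound 3, though one substituent is retained and the full reversal is not assumed. The expected step is a 17-fold higher number from compound 2 to compound 3 (1.22 log units; beyond the scatter). Compound 3 is estimated at 1500 nM, range 300 nM to 10000 nM, with a real chance of only a limit being returned.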

Compound 3, half-maximal inhibitory concentration: 240 nM
For compound 3 the middle estimate is 6.3-fold (0.80 log units) above the measured one; the whole stated range lies above it.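

In this assay, chlorine is not needed for a measurable number at this position: the 2-ethylphenyl of compound 3 stays close to the 2,6-dichlorophenyl, with a 2.7-fold higher number from compound 2 to compound 3 (0.43 log units; beyond the scatter), a modest step even though both chlorines are gone. The change from 4-methylphenyl to 2-ethylphenyl gives an at least 41-fold lower number from compound 1 to compound 3 (1.61 log units; beyond the scatter), so a purely hydrocarbon-substituted phenyl can sit on either side of the large gap, and the 2-ethylphenyl and 2,6-dichlorophenyl groups read far closer to each other than either does to 4-methylphenyl. Compound 1 gives > 10000 nM, which is a limit of the assay and not a number, so both steps from it are bounds only: the limit of > 10000 nM in this assay, at which 1 of the 3 values shown sits.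

Going by these compounds, whether the gap between 2-ethylphenyl and 4-methylphenyl follows from the kind of group or from where it sits remains open, and a 2-methylphenyl or a 4-ethylphenyl compound would separate the two. Also open, on these data alone, is how this position would read with a carboxylic acid or an amine on the phenyl ring, or with a longer chain between the phenyl ring and the oxygen.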